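Swapping the Ring Group on the Core Nitrogen

The compounds below may be only part of what the source reports. "The series", "measured", "known", "first", "only" and "open" are said of these compounds alone.

Compound 1 `CC(C)c1onc(-c2c(Cl)cccc2Cl)c1COc1ccc(-c2nc3ccc(C(=O)O)cc3n2C(C)C)cc1` gives 3550 nM in an assay on HEK-293T cells for antagonist activity at vitamin D3 receptor (Homo sapiens), read by a luciferase reporter, with a stated time of 24 h; a higher number here means a weaker inhibitor, a lower number a stronger inhibitor.
Compound 2 `CC(C)c1onc(-c2c(Cl)cccc2Cl)c1COc1ccc(-c2nc3ccc(C(=O)O)cc3n2CC2CC2)cc1` gives 2650 nM in this assay.
Compound 3 `CC(C)c1onc(-c2c(Cl)cccc2Cl)c1COc1ccc(-c2nc3ccc(C(=O)O)cc3n2C)cc1Cl` gives 2450 nM in this assay.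

Among these three numbers, compound 2 stands second highest; compound 3 lies nearest to it and compound 1 furthest, and both gaps fall within the usual scatter of repeated measurements, so the three compounds cannot really be told apart. Compound 4 `CC(C)c1onc(-c2c(Cl)cccc2Cl)c1COc1ccc(-c2nc3ccc(C(=O)O)cc3n2C2CCCCC2)cc1` differs from compound 2 in one place: cyclohexyl in place of cyclopropylmethyl on an aromatic nitrogen. Within the data shown here, a single earlier step bears on this change, the only one in which the group on an aromatic nitrogen of the shared core was exchanged: a 1.3-fold lower number from compound 1 to compound 2 (0.13 log units; within the scatter). That exchange left the number within the scatter. With nothing else to go on, no step beyond the scatter is expected in this assay in either direction, and the expected step is a 1.0-fold lower number from compound 2 to compound 4 (0.01 log units; within the scatter). Compound 4 is therefore estimated at 2600 nM, with a range from 1000 nM to 7000 nM.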

Compound 4, half-maximal inhibitory concentration: 1450 nM
Compound 4: middle estimate off by 1.8-fold (0.25 log units), on the high side; the range from low to high includes it.
By their numbers in this assay, from the lowest: compounds 4, 3, 2 and 1 (each within the scatter of the next, the first and the last beyond it).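

In this assay the group on this aromatic nitrogen now gives a step beyond the scatter, though a modest one, with a 2.4-fold lower number from compound 1 to compound 4 (0.39 log units; beyond the scatter) when cyclohexyl takes the place of isopropyl. The change to cyclohexyl from cyclopropylmethyl, by contrast, gives a 1.8-fold lower number from compound 2 to compound 4 (0.26 log units; within the scatter) and so stays within the scatter, which means that a six-membered carbon ring is accepted at this position and stands apart only from isopropyl. Nothing measured here explains either step.

As far as these compounds go, whether a still larger ring such as cycloheptyl, or an aromatic phenyl ring, would lower the number further remains open. So does the effect of a longer chain such as n-butyl, or of an amine or hydroxyl group carried on the cyclohexyl ring.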